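Carbamate chain length on the shared piperazine core

The compounds below may be only part of what the source reports. "The series", "measured", "known", "first", "only" and "open" are said of these compounds alone.

Compounds measured so far in a functional assay (Oryctolagus cuniculus) for inhibition of platelet-activating factor receptor (Cavia porcellus); on this read-out lower numbers stand for stronger inhibition and higher numbers for weaker inhibition:
compound 1 `CCCCCCCCCC(=O)OCC1CN(C(=O)c2cc(OC)c(OC)c(OC)c2)CCN1C(=O)c1cc(OC)c(OC)c(OC)c1` gives 2820 nM
compound 2 `CCCCNC(=O)OCC1CN(C(=O)c2cc(OC)c(OC)c(OC)c2)CCN1C(=O)c1cc(OC)c(OC)c(OC)c1` gives 240 nM
compound 3 `CCCC(C)NC(=O)OCC1CN(C(=O)c2cc(OC)c(OC)c(OC)c2)CCN1C(=O)c1cc(OC)c(OC)c(OC)c1` gives 100 nM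

Compound 3 stands lowest of the three numbers in this assay. Its nearest neighbour is compound 2, a step of a 2.4-fold lower number from compound 2 to compound 3 (0.38 log units; beyond the scatter); its furthest is compound 1, a step of a 28-fold lower number from compound 1 to compound 3 (1.45 log units; beyond the scatter). Both steps lie beyond the scatter.

The next compound, compound 4 `CCCCCCCCNC(=O)OCC1CN(C(=O)c2cc(OC)c(OC)c(OC)c2)CCN1C(=O)c1cc(OC)c(OC)c(OC)c1`, differs from compound 3 in one place: octyl in place of 1-methylbutyl on an amide-type nitrogen. The branched chain leaves and a longer straight chain enters on the carbamate nitrogen; the carbamate itself is kept.

Among the compounds with values here, two measured steps bear on this. The step of a 2.4-fold lower number from compound 2 to compound 3 (0.38 log units; beyond the scatter) shows that adding the methyl branch gave a modest gain, so removing it in compound 4 should cost about that much. The step of a 12-fold lower number from compound 1 to compound 2 (1.07 log units; beyond the scatter) is large but changes the ester to a carbamate together with the chain, so it says little about chain length alone; compound 1, with the longest chain, has the highest number, but that pairing is not separable here.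

Compound 4 is therefore expected to sit somewhat weaker than compound 3, a step of a 2.5-fold higher number from compound 3 to compound 4 (0.40 log units; beyond the scatter) in this assay. The estimate for compound 4 in this assay is 250 nM, within a range from 80 nM to 800 nM.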

Compound 4, half-maximal inhibitory concentration: 370 nM
For compound 4 the middle estimate is 1.5-fold (0.17 log units) below the measured one; measured number inside the range.
By their numbers in this assay, from the lowest: compound 3; then compounds 2 and 4 (each within the scatter of the next); then compound 1.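

Chain length on the amide-type nitrogen gives no readable difference in this assay: butyl and octyl, with a 1.5-fold higher number from compound 2 to compound 4 (0.19 log units; within the scatter), cannot be ordered, whereas octyl in place of 1-methylbutyl gives a 3.7-fold higher number from compound 3 to compound 4 (0.57 log units; beyond the scatter), so among the carbamates shown compound 3 alone stands apart, and chain length by itself does not separate the other two. Changing the ester to the octyl carbamate gives a 7.6-fold lower number from compound 1 to compound 4 (0.88 log units; beyond the scatter); with a long chain on both sides of this pair, most of the gap seen earlier between the ester and the shorter carbamate remains. Nothing measured here accounts for either step.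

Still open, on these data alone, is whether a methyl branch on an octyl chain would lower the number as it does on the butyl chain, and whether a shorter chain such as ethyl or a ring such as cyclohexyl on the same nitrogen would hold the level of compound 3. The ester side rests on compound 1 alone, so a shorter chain on the ester would be needed to show whether chain length matters there.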